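The compounds below may be only part of what the source reports. "The series", "measured", "known", "first", "only" and "open" are said of these compounds alone.

Working notes on the series. In a functional assay on BXPC-3 cells (Homo sapiens) for inhibition, read by MTT assay, with a stated time of 72 h (a lower number here means a stronger inhibitor, a higher number a weaker inhibitor), compound 1 `Cc1cnc(C(=O)Nc2cc(OCCNC(=O)OC(C)(C)C)cc3cccnc23)cn1` gives 3670 nM. Compound 2 `Cc1cnc(C(=O)Nc2cc(OCCN)cc3cccnc23)cn1` reaches only a limit in this assay, > 10000 nM. Compound 3 `CC(C)(C)OC(=O)NCCOc1cc(NC(=O)c2ncccn2)c2ncccc2c1` likewise reaches only a limit in this assay, > 10000 nM. Two of the three values therefore sit at the limit of > 10000 nM in this assay, at which 2 of the 3 values shown sit. The cores of compound 1 and compound 3 differ as follows: pyrimidin-2-yl in place of 5-methylpyrazin-2-yl on a carbonyl carbon, which made an at least 2.7-fold higher number from compound 1 to compound 3 (0.43 log units; beyond the scatter). The change hydrogen in place of tert-butoxycarbonyl on an amine nitrogen made an at least 2.7-fold higher number from compound 1 to compound 2 (0.43 log units; beyond the scatter). Compound 4 `NCCOc1cc(NC(=O)c2ncccn2)c2ncccc2c1` has not yet been measured in this assay; it differs from compound 3 by hydrogen in place of tert-butoxycarbonyl on an amine nitrogen, the same change, at the same place. For compound 4 the expected step is a step that the limit leaves unreadable from compound 3 to compound 4, resting on an at least 2.7-fold higher number from compound 1 to compound 2 (0.43 log units; beyond the scatter) and on the limit already reached by compound 3 with > 10000 nM. Compound 4 is estimated at 25000 nM, between 9000 nM and 80000 nM, most likely reported as a limit only.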

Compound 4, half-maximal inhibitory concentration: > 10000 nM
Compound 4 ended at the assay's limit; the forecaster's own chance of this, stated with the estimate: 90%; the middle value lies beyond the limit too.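

Compound 4 also ends at a limit, so no step from compound 3 or compound 2 to compound 4 can be read: the limit of > 10000 nM in this assay, at which 3 of the 4 values shown sit.

Going by these compounds, whether hydrogen in place of tert-butoxycarbonyl changes anything in the pyrimidin-2-yl compounds stays open.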